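From 4-methylbenzyl to 4-chlorobenzyl on compound 1

This account rests on a few compounds, and the source may have more. Where it says the series, first, only, none or still open, it means among the compounds named here.

Compound 1 `COc1cc(CNCc2ccncc2)ccc1OCc1ccc(C)cc1`: 5000 nM
Compound 2 `COc1cc(CNc2nc[nH]n2)ccc1OCc1ccc(Cl)nc1`: 69000 nM
Compound 3 `COCCNCc1ccc(OCc2ccc(Cl)nc2)c(OC)c1`: 97000 nM

All three compounds were measured in a functional assay on HeLa cells (Homo sapiens) for inhibition, with a stated time of 72 h; on this read-out higher numbers stand for an effect only at larger amounts of compound and lower numbers for an effect already at smaller amounts. Compound 1 has the lowest number of the three, at 5000 nM, and its gaps to compound 2 and compound 3 both lie beyond the scatter.

Compound 4 `COc1cc(CNCc2ccncc2)ccc1OCc1ccc(Cl)cc1` keeps the core of compound 1 and alters one group: chloro in place of methyl on an aromatic carbon. This is chloro in place of methyl on an aromatic carbon, turning 4-methylbenzyl into 4-chlorobenzyl.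

For the measured compounds named here, the only measured step, a 1.4-fold higher number from compound 2 to compound 3 (0.15 log units; within the scatter), lies within the scatter and concerns a different place, a group on an amine nitrogen, so it bears only indirectly on this change. Compound 2 and compound 3 also carry a chloro, but they differ from compound 1 in more than that group, so their higher numbers cannot be credited to it. Going by the values given here, no measured pair sets chloro directly against methyl.

With no evidence pointing either way, no step beyond the scatter is expected in this assay, and the expectation stays anchored on compound 1 at 5000 nM. The expected change is a 1.1-fold lower number from compound 1 to compound 4 (0.05 log units; within the scatter). For compound 4 the estimated value is 4500 nM, with an expected range from 1500 nM to 13000 nM.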

Compound 4, half-maximal effective concentration: 890 nM
Estimate against measurement, compound 4: 5.1-fold (0.70 log units) above, outside the stated range (below it).
By their numbers in this assay, from the lowest: compound 4; then compound 1; then compounds 2 and 3 (each within the scatter of the next).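

In this assay, the position para to a large group on the six-membered aromatic ring of carbon only turns out not to be indifferent to what it carries: chloro in place of methyl gives a 5.6-fold lower number from compound 1 to compound 4 (0.75 log units; beyond the scatter). For the compounds shown here, the earlier compounds could not show this, since the one step among them concerned a group on an amine nitrogen and stayed within the scatter, and no pair set chloro directly against methyl. The change is small by count, one heavy atom for one heavy atom with no hydrogen-bond donors or acceptors on either side, yet the step lies beyond the scatter, and nothing measured here accounts for it.

The compounds shown leave open whether a fluoro, a bromo or a methoxy at this place would read closer to compound 4 or to compound 1, so a single pair gives no trend across groups. They also leave open whether chloro in place of methyl would give a similar step with a different group on the amine nitrogen, such as 2-methoxyethyl.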